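A few compounds are considered here, and "the series" means these few. Any claim that something is new, unique, unknown or untested is made for them only; others in the source may bear on it.

Measured so far:
compound 1 `COc1ccc(Oc2ccc3c(NCCCNCc4cc(F)ccc4OC)ccnc3c2)cc1`: 317 10^-6 cm/s
compound 2 `COc1cccc(CNCCCNc2ccnc3cc(Cc4ccc(F)cc4)ccc23)c1O`: 23 10^-6 cm/s

In an ADME assay for permeability, using PAMPA, with a stated time of 30 min, at pH 7.4 (a lower number here means that the compound crosses the layer more slowly, a higher number that the compound crosses the layer faster), compound 1 gives 317 10^-6 cm/s, the higher of the two numbers recorded. Compound 2 gives 23 10^-6 cm/s, a gap that lies beyond the scatter, so the two compounds sit clearly apart in this assay.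

Compound 3 `COc1ccc(F)cc1CNCCCNc1ccnc2cc(Cc3ccccc3)ccc12` has not yet been measured. It differs from compound 1 in one place: benzyl in place of 4-methoxyphenoxy on an aromatic carbon. Among the measured compounds shown here, no step between measured compounds of this kind is on record, so the direction has to be judged from what is at hand. Given how high compound 1 stands at 317 10^-6 cm/s, a modest step downward is expected, likely near the edge of the scatter rather than far beyond it, with the step from compound 1 to compound 3 estimated at a 2.1-fold lower number from compound 1 to compound 3 (0.32 log units; beyond the scatter). Compound 3 is accordingly expected to give 150 10^-6 cm/s, within a range of 40 10^-6 cm/s to 400 10^-6 cm/s.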

Compound 3, apparent permeability: 23 10^-6 cm/s
Estimate against measurement, compound 3: 6.5-fold (0.81 log units) above; measured number outside the range, below it.
By their numbers in this assay, from the lowest: compounds 2 and 3 (each within the scatter of the next); then compound 1.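

In this assay, putting benzyl in place of 4-methoxyphenoxy on this aromatic carbon gives a 14-fold lower number from compound 1 to compound 3 (1.14 log units; beyond the scatter) as a large step beyond the scatter, so the read-out is sensitive to the group held here. Both groups carry one six-membered aromatic ring of carbon only, so that ring is common to the two, while the 2 hydrogen-bond acceptors of 4-methoxyphenoxy are absent from benzyl. No measurement on hand accounts for the size of this step and it remains an observation on a single pair.

The compounds shown do not separate the part played by the methoxy group from that of the oxygen joining the ring to the core. A plain phenoxy group or a 4-methoxybenzyl group on this carbon would tell those two apart.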